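A cyano swap at the limit of the assay

A few compounds are considered here, and "the series" means these few. Any claim that something is new, unique, unknown or untested is made for them only; others in the source may bear on it.

Compound 1 `COc1ccc(/C=C/[C@@](C)(/C=C/c2ccc(O)cc2)CCC=C(C)C)cc1`: > 36600 nM
Compound 2 `CCOc1ccc(/C=C/[C@@](C)(/C=C/c2ccc(O)cc2)CCC=C(C)C)cc1`: > 36600 nM
Compound 3 `CC(C)=CCC[C@@](C)(/C=C/c1ccc(C)cc1)/C=C/c1ccc(O)cc1`: > 36600 nM

Each entry above is a limit of a functional assay on SEM cells (Homo sapiens) for cytotoxicity, with a stated time of 72 h (on this read-out higher numbers stand for an effect only at larger amounts of compound and lower numbers for an effect already at smaller amounts), and not a number. The whole series stands there: the limit of > 36600 nM in this assay, at which 3 of the 3 values shown sit. Compound 3 thus has no exact place, only its limit of > 36600 nM.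

The next compound, compound 4 `CC(C)=CCC[C@](C)(/C=C/c1ccc(O)cc1)/C=C/c1ccc(C#N)cc1`, has cyano in place of methyl on an aromatic carbon, para to a large group (cyano in place of methyl on an aromatic carbon). Two measured changes involve the same kind of aromatic carbon, with methyl in place of methoxy and methyl in place of ethoxy: a step that the two limits leave unreadable from compound 1 to compound 3 and a step that the two limits leave unreadable from compound 2 to compound 3. Among the measured compounds shown here, neither has a readable size, and none of the measured compounds carries cyano, so they offer no direction for this change.

For the measured compounds named here, compound 4 is expected to stay near the limit in this assay, since the only guide is the limit of > 36600 nM in this assay, at which 3 of the 3 values shown sit. The expected result is a step that the limit leaves unreadable from compound 3 to compound 4, which is no clear change. For compound 4 the estimate is 40000 nM, within an expected range from 15000 nM to 80000 nM.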

Compound 4, half-maximal effective concentration: > 36600 nM
Compound 4: a limit, no number; the forecaster's own chance of this, stated with the estimate: 80%; the middle value does not contradict the limit.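

In this assay compound 4 gives > 36600 nM, a limit and not a number, so its steps from compound 1, compound 2 and compound 3 cannot be read. Left open is whether changing this group affects cytotoxicity at all, because every compound shares one ceiling: the limit of > 36600 nM in this assay, at which 4 of the 4 values shown sit.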